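The compounds below may be only part of what the source reports. "The series", "measured", "known", "first", "only" and "open" are said of these compounds alone.

Measured so far:
compound 1 `CN1CCCc2ccc(NC(=O)c3ccc(-c4ccccc4)cc3)cc21`, 7.5
compound 2 `CC(=O)NCCN1CCCc2ccc(NC(=O)c3ccc(-c4ccccc4)cc3)cc21`, 6.9

Compound 1 is the stronger of the two compounds measured in a functional assay for antagonist activity at transient receptor potential cation channel subfamily V member 1 (Homo sapiens), read by FLIPR and calcium flux; a lower number here means a less potent compound, a higher number a more potent compound, by a factor of ten per unit of this negative logarithm. Compound 2 carries an acetamidomethyl in place of hydrogen on a saturated chain carbon bound to the ring nitrogen of the shared core, and the number moves a number 0.60 log units lower from compound 1 to compound 2 (beyond the scatter).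

Compound 3 `CN1CCCc2ccc(NC(=O)c3ccc(-c4cnccn4)cc3)cc21` is not yet measured. It differs from compound 1 at the far end of the molecule: pyrazin-2-yl in place of phenyl on an aromatic carbon. Going by the values given here, the only measured step, from compound 1 to compound 2, changes the other end of the structure and so does not bear directly on this exchange; no measured pair shows what swapping the terminal ring does here. The expectation therefore rests on the structural change alone. Exchanging a plain aromatic ring for one bearing two ring nitrogens is a small change in size but adds two acceptors, and the expected outcome for compound 3 is a step of a number 0.40 log units lower from compound 1 to compound 3 (beyond the scatter), at the edge of the scatter and with a wide range. For compound 3 the estimate in this assay is 7.1, from 6.3 to 7.8.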

Compound 3, negative logarithm of the antagonist equilibrium constant: 7.1
The estimate for compound 3 equals the measured number at the digits printed, within the range that was stated.
By their numbers in this assay, from the lowest: compounds 2 and 3 (each within the scatter of the next); then compound 1.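

The earlier step touched only the substituent on the ring nitrogen of the shared core, whereas here the terminal ring changes, and in this assay pyrazin-2-yl in place of phenyl gives a number 0.40 log units lower from compound 1 to compound 3 (beyond the scatter). The leaving and entering rings have the same number of heavy atoms and neither carries a net charge, so this position, on an aromatic carbon and para to a large group, responds to a change of ring atoms without a change in heavy-atom count, and compound 3 still gives 7.1. Nothing measured here says why the number moves with this exchange.

A single exchange cannot separate the contribution of each ring nitrogen, so the compounds shown leave open how a pyridinyl or pyrimidinyl ring would compare with phenyl and pyrazin-2-yl at this position. They also leave open whether a saturated ring such as morpholine would be accepted here, and whether the terminal ring and the chain on the ring nitrogen act independently when both are changed in one compound.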